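Lengthening the Nitrogen Chain of Compound 3

This account rests on a few compounds, and the source may have more. Where it says the series, first, only, none or still open, it means among the compounds named here.

In a functional assay on the whole organism with Mus musculus as the target (a higher number here means that more compound is needed for the effect, a lower number that less compound is needed), compound 3 (`CN1C(=O)CCC1(O)c1cccc(C(F)(F)F)c1`) gives 51.6 mg/kg and so stands within the scatter of both other measured compounds: compound 1 (`NC(=O)/C=C/c1cccc(C(F)(F)F)c1`) gives 49.5 mg/kg here and compound 2 (`CCC(O)CNC(=O)/C=C/c1cccc(C(F)(F)F)c1`) gives 64.4 mg/kg here. Compound 4 (`CCCCN1C(=O)CCC1(O)c1cccc(C(F)(F)F)c1`) carries propyl in place of hydrogen on a saturated chain carbon bound to an amide-type nitrogen in a ring, so that methyl becomes butyl. Going by the values given here, the only measured step that bears on this, and only loosely, is 2-hydroxybutyl in place of hydrogen on an amide-type nitrogen, which gave a 1.3-fold higher number from compound 1 to compound 2 (0.11 log units; within the scatter) in this assay and stayed small. No step beyond the scatter is therefore expected, and the estimated change is a 1.0-fold higher number from compound 3 to compound 4 (0.00 log units; within the scatter) at most modest. The estimate for compound 4 is 52 mg/kg as the expected value, with 25 mg/kg and 105 mg/kg as the expected ends of its range.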

Compound 4, dose for half-maximal effect: 183 mg/kg
The estimate for compound 4 lay 3.5-fold (0.55 log units) below the measured number; the measured number lies above the stated range.
By their numbers in this assay, from the lowest: compounds 1, 3 and 2 (each within the scatter of the next); then compound 4.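

In this assay, going by these compounds alone, the group on this ring nitrogen proves to matter: going from methyl to butyl gives a 3.5-fold higher number from compound 3 to compound 4 (0.55 log units; beyond the scatter) and is the first step here beyond the scatter. Within the data shown here, the only earlier step, a 1.3-fold higher number from compound 1 to compound 2 (0.11 log units; within the scatter) on a different core, stayed within the scatter and gave no sign of this sensitivity. No available evidence explains the rise.
On these data alone, it remains open whether an ethyl chain would fall between compound 3 and compound 4. Also open, as far as these compounds go, is how a butyl chain ending in an amine or a carboxylic acid would compare.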